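Para-Chloro for Para-Methyl on Two Related Triterpenoid Cores

The compounds below may be only part of what the source reports. "The series", "measured", "known", "first", "only" and "open" are said of these compounds alone.

Compound 1 `CC1=CC[C@H]2[C@H](CC[C@]2(C)O)C(C)(C)[C@@H]1CC[C@H]1[C@]2(C)CC[C@H](OC(=O)c3ccc(C)cc3)C(C)(C)O[C@H]2CC[C@@]1(C)O` and compound 2 `CC1=CC[C@H]2[C@H](CC[C@]2(C)O)C(C)(C)[C@@H]1CC[C@H]1[C@]2(C)CC[C@H](OC(=O)c3ccc(Cl)cc3)C(C)(C)O[C@H]2CC[C@@]1(C)O` share one core and differ only in the aromatic ester. In a functional assay on MDA-MB-231 cells (Homo sapiens) for antiproliferative activity, read by MTT assay, with a stated time of 72 h (a lower number here means a stronger inhibitor, a higher number a weaker inhibitor), compound 1 gives 33400 nM, and compound 2 gives 10300 nM. The change between them, chloro in place of methyl on an aromatic carbon, made a step of a 3.2-fold lower number from compound 1 to compound 2 (0.51 log units; beyond the scatter).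

Compound 3 `CC1=CC[C@H]2[C@@H]1CC=C(C)[C@@H](CC[C@H]1[C@]3(C)CC[C@H](OC(=O)c4ccc(C)cc4)C(C)(C)O[C@H]3CC[C@@]1(C)O)C2(C)C` carries a second core; how it differs from the core of compound 1 is not broken down here. In this assay compound 3 gives 32700 nM, which sits close to the number for compound 1 and well above that for compound 2.

Compound 4 `CC1=CC[C@H]2[C@@H]1CC=C(C)[C@@H](CC[C@H]1[C@]3(C)CC[C@H](OC(=O)c4ccc(Cl)cc4)C(C)(C)O[C@H]3CC[C@@]1(C)O)C2(C)C` stands to compound 3 as compound 2 stands to compound 1: the same change, chloro in place of methyl on an aromatic carbon, para to a large group, has not yet been measured on this core. Among the compounds with values here, because the single earlier example gave a 3.2-fold lower number from compound 1 to compound 2 (0.51 log units; beyond the scatter), the account expects a step of about a 3.0-fold lower number from compound 3 to compound 4 (0.47 log units; beyond the scatter) from compound 3 to compound 4. Within the data shown here, with only one precedent, the range is kept wide. For compound 4 the expected value in this assay is 11000 nM, between 5000 nM and 26000 nM.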

Compound 4, half-maximal inhibitory concentration: 12700 nM
Estimate against measurement, compound 4: 1.2-fold (0.06 log units) below; low and high end bracket the measured number.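

In this assay, the change from 4-methylphenyl to 4-chlorophenyl on the second core again lowered the number, giving a 2.6-fold lower number from compound 3 to compound 4 (0.41 log units; beyond the scatter). Set beside the first example, the two steps agree, which shows that in this series the change carried over from one core to the other with its size preserved: the same change on two cores in this assay, a 3.2-fold lower number (0.51 log units; beyond the scatter) from compound 1 to compound 2 and a 2.6-fold lower number (0.41 log units; beyond the scatter) from compound 3 to compound 4, 1.3-fold (0.10 log units) apart, within the scatter of two such steps This agreement rests on only two matched pairs in a single cell assay, so it gives no rule for other cores or other cell lines, and it does not explain why the number falls when chloro replaces methyl.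

Every ester shown carries either methyl or chloro in this place, which leaves open whether fluoro, bromo, methoxy or an amine there would shift the number in the same way on both cores. Also open, going by these compounds, is whether the step would hold if an amide took the place of the ester link.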